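This account rests on a few compounds, and the source may have more. Where it says the series, first, only, none or still open, it means among the compounds named here.

Measured so far in a functional assay on T47D cells (Homo sapiens) for antiproliferative activity, read by MTT assay, with a stated time of 72 h; on this read-out higher numbers stand for weaker inhibition and lower numbers for stronger inhibition:
compound 1, `CCn1ccnc1-c1cc(OC)c(OC)c(OC)c1`, gives > 100000 nM, a limit of the assay.
compound 2, `COc1cc(-c2nccn2C(C)C)cc(OC)c1OC`, gives > 100000 nM, a limit of the assay.
compound 3, `COc1cc(-c2nccn2CC(C)C)cc(OC)c1OC`, gives > 100000 nM, a limit of the assay.

Compound 3 stands at the limit, as do the other two members of the series: the limit of > 100000 nM in this assay, at which 3 of the 3 values shown sit. The steps among them, a step that the two limits leave unreadable from compound 1 to compound 2, a step that the two limits leave unreadable from compound 1 to compound 3 and a step that the two limits leave unreadable from compound 2 to compound 3, are therefore unreadable in size and direction. Every change so far has exchanged one saturated chain on the aromatic nitrogen for another.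

Compound 4, `COc1cc(-c2nccn2-c2ccc(C)cc2)cc(OC)c1OC`, differs from compound 3 as follows: 4-methylphenyl in place of isobutyl on an aromatic nitrogen. Among the measured compounds shown here, no measured step bears on bringing a six-membered aromatic ring onto that nitrogen; the three unreadable steps give no size to lean on. The expectation in this assay is that compound 4 stays at or near the limit, with only a loose chance of a readable number; the step of an at least 1.2-fold lower number from compound 3 to compound 4 (0.09 log units; that floor lies within the scatter) is the expected size. Compound 4 is estimated at 80000 nM, with a range from 10000 nM to 100000 nM.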

Compound 4, half-maximal inhibitory concentration: 20500 nM
For compound 4 the middle estimate is 3.9-fold (0.59 log units) above the measured one; the measured number falls inside the stated range.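

In this assay, among the compounds shown here, the aromatic nitrogen proves able to carry a change that shifts the read-out: 4-methylphenyl gives the first number that is not a limit, with an at least 4.8-fold lower number from compound 3 to compound 4 (0.68 log units; beyond the scatter) and an at least 4.8-fold lower number from compound 2 to compound 4 (0.68 log units; beyond the scatter) and an at least 4.8-fold lower number from compound 1 to compound 4 (0.68 log units; beyond the scatter) all beyond the scatter. Each of these sizes is only a floor, and a true size cannot be given, since the ethyl, isopropyl and isobutyl compounds are limits: the limit of > 100000 nM in this assay, at which 3 of the 4 values shown sit.

The steps among compound 1, compound 2 and compound 3 cannot be read, so those chains cannot be ordered among themselves. Open too, from the compounds shown here alone, is whether the six-membered aromatic ring alone suffices or its methyl also counts, a question that plain phenyl, benzyl or a pyridyl ring on that nitrogen would bear on.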